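Tert-butyl to cyclopentyl: what to expect for compound 4

The compounds below may be only part of what the source reports. "The series", "measured", "known", "first", "only" and "open" are said of these compounds alone.

Compound 1 `CCS(=O)(=O)Nc1ccc2c(c1)S(=O)(=O)N=C(c1c(O)c(-c3cccs3)nn(CCC(C)C)c1=O)N2` was run in an ADME assay on Huh-7 cells (Homo sapiens) for cytotoxicity, with a stated time of 72 h; on this read-out higher numbers stand for lower toxicity in this test and lower numbers for higher toxicity in this test. In this assay compound 1 reaches only an assay limit, > 33000 nM. Compound 2 `CC(C)=Cc1nn(CCC(C)C)c(=O)c(C2=NS(=O)(=O)c3cc(NS(C)(=O)=O)ccc3N2)c1O` in this assay likewise stops at a limit, > 1000 nM. Compound 3 `CC(C)(C)CCn1nc(-c2cccs2)c(O)c(C2=NS(=O)(=O)c3cc(NS(C)(=O)=O)ccc3N2)c1=O` in this assay also gives only a limit, > 1000 nM. Compound 3 thus stands at the limit of > 1000 nM in this assay, at which 2 of the 3 values shown sit. Compound 1 stands at the limit of > 33000 nM in this assay, at which 1 of the 3 values shown sits. None of the three has a true number. Compound 4 `CS(=O)(=O)Nc1ccc2c(c1)S(=O)(=O)N=C(c1c(O)c(-c3cccs3)nn(CCC3CCCC3)c1=O)N2` differs from compound 3 by cyclopentyl in place of tert-butyl on a saturated chain carbon, two bonds along the chain from an aromatic nitrogen. For the measured compounds named here, no step between measured compounds is available, so the expected step in this assay is a step that the limit leaves unreadable from compound 3 to compound 4, none beyond the scatter. Compound 4 is estimated at 3000 nM in this assay, within 1000 nM to 10000 nM, most probably again reported only as a limit.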

Compound 4, half-maximal cytotoxic concentration: > 1000 nM
Compound 4 was reported as a limit (the forecaster's own chance of this, stated with the estimate: 80%); the middle value lies beyond the limit too.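

Compound 3 and compound 4 both stop at an assay limit in this assay, and no step can be read between them. The compounds shown leave open whether cyclopentyl in place of tert-butyl changes the true half-maximal cytotoxic concentration at all.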